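This account rests on a few compounds, and the source may have more. Where it says the series, first, only, none or still open, it means among the compounds named here.

In a functional assay on Raji cells (Homo sapiens) for inhibition, read by MTT assay, with a stated time of 72 h (on this read-out lower numbers stand for stronger inhibition and higher numbers for weaker inhibition), compound 1 (`CO[C@@H](c1ccccc1)[C@H]1O[C@@H]2CC(=O)O[C@@H]2[C@H]1O`) gives 21100 nM and compound 2 (`CO[C@@H]1[C@H]2OC(=O)C[C@H]2O[C@@H]1C(O)(c1ccccc1)c1ccccc1`) gives 19000 nM, so these two values lie within the usual scatter of each other. Compound 3 (`CO[C@H](c1ccccc1)[C@H]1O[C@@H]2CC(=O)O[C@@H]2[C@H]1O`) differs from compound 1 only in configuration as drawn (the two compounds have the same atoms and bonds and differ only in configuration as drawn: 1 of 5 stereo elements differ; a stereocentre at a saturated chain carbon is drawn S in compound 1 and R in compound 3): a stereocentre at a saturated chain carbon is drawn S in compound 1 and R in compound 3. Going by the values given here, no measured pair shows what such a change does in this assay, so no step beyond the scatter is expected, in either direction. The estimated step is a 1.2-fold lower number from compound 1 to compound 3 (0.09 log units; within the scatter). The expected value for compound 3 is 17000 nM, within an estimated range of 6000 nM to 45000 nM.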

Compound 3, half-maximal inhibitory concentration: 15600 nM
Beside the measured number, compound 3's estimate is 1.1-fold (0.04 log units) above it, and the stated range covers the measured number.
By their numbers in this assay, from the lowest: compounds 3, 2 and 1 (each within the scatter of the next).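

Compounds 1 and 2 could not offer a direct look at a change in configuration. In this assay, the new pair gives the first such look: a 1.4-fold lower number from compound 1 to compound 3 (0.13 log units; within the scatter). Drawing this stereocentre at a saturated chain carbon as R rather than S therefore leaves the read-out within the usual scatter. The comparison is a clean one, with a single point of difference: the fact that compounds 1 and 3 differ only in the configuration as drawn.

As far as these compounds go, whether the other stereo elements of the shared core tolerate inversion equally well remains open. So does whether this stereocentre would matter if it carried an amine or a carboxylic acid.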